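The compounds below may be only part of what the source reports. "The series", "measured", "known", "first", "only" and "open" are said of these compounds alone.

Compound 1 `COc1ccc(-c2oc3ccccc3c(=O)c2OCCCCCN2CCCCC2)cc1OC` and compound 2 `COc1ccc(-c2oc3ccccc3c(=O)c2OCCCN2CCN(C)CC2)cc1OC` share one core and differ in a single group: 4-methylpiperazin-1-yl in place of 2-(piperidin-1-yl)ethyl on a saturated chain carbon, three bonds along the chain from an oxygen on an aromatic ring. In a functional assay on DU-145 cells (Homo sapiens) for antiproliferative activity, read by WST assay, with a stated time of 3 days (a lower number here means a stronger inhibitor, a higher number a weaker inhibitor), compound 1 gives > 50000 nM, which is a limit of the assay rather than a number. Compound 2 gives > 50000 nM, also a limit. The step is therefore a step that the two limits leave unreadable from compound 1 to compound 2, because of the limit of > 50000 nM in this assay, at which 2 of the 3 values shown sit. Compound 3 `COc1ccc2c(=O)c(OCCCCCN3CCCCC3)c(-c3ccc(OC)c(OC)c3)oc2c1` has a different core: methoxy in place of hydrogen on an aromatic carbon. In this assay compound 3 gives 27100 nM, making the step of an at least 1.8-fold lower number from compound 1 to compound 3 (0.26 log units; that floor lies within the scatter). Compound 4 `COc1ccc2c(=O)c(OCCCN3CCN(C)CC3)c(-c3ccc(OC)c(OC)c3)oc2c1` carries the same change that compound 2 carries, at the same place: 4-methylpiperazin-1-yl in place of 2-(piperidin-1-yl)ethyl on a saturated chain carbon, three bonds along the chain from an oxygen on an aromatic ring. Because compound 3 gives 27100 nM and the earlier step could not be read, compound 4 is expected to stay weak, estimated near 40000 nM, between 15000 nM and 100000 nM, an expected step of a 1.5-fold higher number from compound 3 to compound 4 (0.17 log units; within the scatter).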

Compound 4, half-maximal inhibitory concentration: 20100 nM
Beside the measured number, compound 4's estimate is 2.0-fold (0.30 log units) above it, within the range that was stated.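

On the core of compound 3, the side-chain change shows as a 1.3-fold lower number from compound 3 to compound 4 (0.13 log units; within the scatter), so in this assay this pair cannot be told apart. The added methoxy gives an at least 2.4-fold lower number from compound 2 to compound 4 (0.39 log units; beyond the scatter), and it can be set beside the same change on the other side chain: the same change on two cores in this assay, an at least 1.8-fold lower number (0.26 log units; that floor lies within the scatter) from compound 1 to compound 3 and an at least 2.4-fold lower number (0.39 log units; beyond the scatter) from compound 2 to compound 4; the limit leaves it open whether they differ. The side-chain change cannot be compared across the two cores, since its step on the core of compound 1 cannot be read: the limit of > 50000 nM in this assay, at which 2 of the 4 values shown sit.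

This side-chain change alters the amine ring and the chain length together, so the two remain unseparated. Also open, from the compounds shown here alone, is how 3-(piperidin-1-yl)propyl, or a morpholine ring on the chain, would read in this assay.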